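Swapping the silicon-bearing group for an amide on the ring

The source may hold more compounds than are shown below. What is called first, only, known or untested is meant among the compounds shown, and "the series" means these compounds.

Compound 2 `CC[Si](CC)(CC)C/C1=C/C[C@](C)(CCC=C(C)C)/C=C/[C@@H](OC(=O)C=C(C)C)[C@](C)(O)/C=C/C1=O` holds the only numeric result in a functional assay on HL-60 cells (Homo sapiens) for antiproliferative activity, read by MTT assay, with a stated time of 48 h; on this read-out lower numbers stand for stronger inhibition and higher numbers for weaker inhibition: compound 2 gives 2810 nM. Compound 1 `CC(C)=CCC[C@]1(C)/C=C/[C@@H](OC(=O)C=C(C)C)[C@](C)(O)/C=C/C(=O)/C(C(=O)O)=C\C1`, which carries a group of 3 heavy atoms (1 carbon, 2 oxygen) on the same double-bonded ring carbon, reaches only a limit of this assay. In this assay compound 1 gives > 10000 nM, a limit rather than a number. For the measured compounds named here, the one measured step, an at least 3.5-fold lower number from compound 1 to compound 2 (0.55 log units; beyond the scatter), rests on that limit (the limit of > 10000 nM in this assay, at which 1 of the 2 values shown sits), so its true size is known only as a floor. Compound 3 `CCN(CC)C(=O)/C1=C/C[C@](C)(CCC=C(C)C)/C=C/[C@@H](OC(=O)C=C(C)C)[C@](C)(O)/C=C/C1=O` differs from compound 2 in one place: a group of 7 heavy atoms (5 carbon, 1 nitrogen, 1 oxygen; no ring) in place of a group of 8 heavy atoms (7 carbon, 1 silicon; no ring), on a double-bonded ring carbon. Going by the values given here, the measured step shows the silicon-bearing group giving a lower number than the oxygen-bearing one, but no measured pair tells how a diethylcarbamoyl fares at this position. Compound 3 is therefore estimated at 4500 nM, with a range from 1500 nM to 14000 nM. For compound 3 the expected step is a 1.6-fold higher number from compound 2 to compound 3 (0.20 log units; within the scatter), with a real chance that compound 3 returns only a limit.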

Compound 3, half-maximal inhibitory concentration: 9080 nM
Estimate against measurement, compound 3: 2.0-fold (0.30 log units) below; low and high end bracket the measured number.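

For the compounds shown here, compound 3 gives the first measured comparison at this double-bonded ring carbon between two groups that both return a number in this assay, and the silicon-bearing group comes out ahead of diethylcarbamoyl: a 3.2-fold higher number from compound 2 to compound 3 (0.51 log units; beyond the scatter). Putting diethylamino in place of hydroxy on the carbonyl carbon gives no readable gain: an at least 1.1-fold lower number from compound 1 to compound 3 (0.04 log units; that floor lies within the scatter). That second step is only a floor, and it rests on a limit of the assay: the limit of > 10000 nM in this assay, at which 1 of the 3 values shown sits.

Still open, from the compounds shown here alone, is whether the silicon atom itself matters, which a chain of carbon only on this ring carbon would test. Also open, going by these compounds, are how a smaller amide such as dimethylcarbamoyl would compare with diethylcarbamoyl and how far compound 1 truly lies from compound 3.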